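A few compounds are considered here, and "the series" means these few. Any claim that something is new, unique, unknown or untested is made for them only; others in the source may bear on it.

Of the compounds shown here, two of one series have so far been measured in a functional assay on L6 cells (Rattus norvegicus) for inhibition; a higher number here means a weaker inhibitor, a lower number a stronger inhibitor. Compound 1 `CC(C)c1c(C(=O)N2CCC[C@H](c3ccccc3)C2)nn(-c2ccc(F)cc2)c1CC[C@@H](O)C[C@@H](O)CC(=O)O` gives 310 nM in this assay . Going by the values given here, compound 2 `CC(C)c1c(C(=O)N2CCCCC2)nn(-c2ccc(F)cc2)c1OC[C@@H](O)C[C@@H](O)CC(=O)O` gives 32200 nM in this assay , the higher of the two numbers, and the only neighbour, compound 1, stands far below it, a gap well beyond the scatter. The two structures differ in more than one place, so the gap cannot be tied to any single change.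

Compound 3 `COc1cccc(CN(C)C(=O)c2nn(-c3ccc(F)cc3)c(OC[C@@H](O)C[C@@H](O)CC(=O)O)c2C(C)C)c1` differs from compound 2 in one place: (3-methoxybenzyl)(methyl)amino in place of piperidin-1-yl on a carbonyl carbon. Among the compounds with values here, no measured pair describes this change, so its effect is open. Within the data shown here, the one compound carrying an aromatic ring on the amide, compound 1, sits far lower at 310 nM, which hints that adding such a ring may help, though compound 1 also differs elsewhere. Compound 3 is therefore expected to move downward from compound 2 by a moderate step, a 4.0-fold lower number from compound 2 to compound 3 (0.60 log units; beyond the scatter). Compound 3 is estimated at 8000 nM, with a range from 1500 nM to 40000 nM.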

Compound 3, half-maximal inhibitory concentration: 9460 nM
Beside the measured number, compound 3's estimate is 1.2-fold (0.07 log units) below it; the range from low to high includes it.
By their numbers in this assay, from the lowest: compound 1; then compound 3; then compound 2.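

On a carbonyl carbon of the shared core, the series now has its first step that can be tied to a single change: in this assay, (3-methoxybenzyl)(methyl)amino in place of piperidin-1-yl gives a 3.4-fold lower number from compound 2 to compound 3 (0.53 log units; beyond the scatter). The position therefore accepts a group of 11 heavy atoms carrying a six-membered aromatic ring of carbon only, and the number falls by a modest step rather than rising. The step reads only as a whole, since the change removes a six-membered non-aromatic ring and adds an aromatic ring, a methyl group and a hydrogen-bond acceptor all at once. No measured evidence here bears on why the number falls.

The compounds shown leave open whether the step belongs to the aromatic ring or to its methoxy group, a question that a benzyl(methyl)amino group lacking the methoxy would separate. They also leave open what the methyl group contributes, which a (3-methoxybenzyl)amino group on the same carbonyl carbon would show.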